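The source may hold more compounds than are shown below. What is called first, only, known or untested is meant among the compounds shown, and "the series" means these compounds.

Compound 1 `C/C(=C\CC/C(C)=C/CC[C@@H]1[C@@]2(C)CCC(=O)C(C)(C)[C@H]2CC[C@@]1(C)O)CC/C=C(\C)C(=O)OCc1cn(-c2ccc([N+](=O)[O-])cc2)nn1`: in a functional assay on A549 cells (Homo sapiens) for antiproliferative activity, read by MTT assay, with a stated time of 48 h (a higher number here means a weaker inhibitor, a lower number a stronger inhibitor), compound 1 gives > 150000 nM, a limit of the assay.
Compound 2 `C/C(=C\CC/C(C)=C/CC[C@@H]1[C@@]2(C)CCC(=O)C(C)(C)[C@H]2CC[C@@]1(C)O)CC/C=C(\C)C(=O)OCc1cn(-c2ccc(F)c(Cl)c2)nn1`: in this assay compound 2 gives > 150000 nM, a limit of the assay.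
Compound 3 `C/C(=C\CC/C(C)=C/CC[C@@H]1[C@@]2(C)CCC(=O)C(C)(C)[C@H]2CC[C@@]1(C)O)CC/C=C(\C)C(=O)OCc1cn(-c2ccc(F)cc2)nn1`: in this assay compound 3 gives > 150000 nM, a limit of the assay.

Compound 3 therefore stands at a limit rather than at a number, and the same is true of the two other measured compounds, as the limit of > 150000 nM in this assay, at which 3 of the 3 values shown sit, shows. Among the measured compounds shown here, none of the measured steps can be read: a step that the two limits leave unreadable from compound 1 to compound 2, a step that the two limits leave unreadable from compound 1 to compound 3 and a step that the two limits leave unreadable from compound 2 to compound 3 all run between limits.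

The untested compound 4 `C/C(=C\CC/C(C)=C/CC[C@@H]1[C@@]2(C)CCC(=O)C(C)(C)[C@H]2CC[C@@]1(C)O)CC/C=C(\C)C(=O)OCc1cn(-c2ccc(C(C)(C)C)cc2)nn1` differs from compound 3 by tert-butyl in place of fluoro on an aromatic carbon. Every measured step rests on limits alone. For the measured compounds named here, no step bearing on this change has a readable size, so no direction can be taken from them; the only available observation is that three variations of the group on the aromatic nitrogen all stayed at the limit. On that footing compound 4 is expected to give 200000 nM in this assay, with a range from 60000 nM to 600000 nM. The expected step is a step that the limit leaves unreadable from compound 3 to compound 4, most likely again reported only as a limit.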

Compound 4, half-maximal inhibitory concentration: > 150000 nM
Compound 4 ended at the assay's limit (the forecaster's own chance of this, stated with the estimate: 80%); the middle value lies beyond the limit too.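

Among the compounds shown here, compound 4 joins compound 1, compound 2 and compound 3 at a limit of the assay, so no step among them can be read in this assay: the limit of > 150000 nM in this assay, at which 4 of the 4 values shown sit. The compounds shown leave open whether any group on the aromatic nitrogen gives a measurable value, and how far these four compounds differ.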